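Swapping the pyridine headgroup of compound 3 for a pyrimidine

The source may report more compounds than this note shows. Statements on the series, on what has been measured and on what is new or still open speak of the compounds shown alone.

All compounds here share one core, a bicyclic ketone joined through a sulfonyl group to a piperazine whose far nitrogen carries an aromatic ring, and all are tested in a functional assay on CHO-K1 cells for antagonist activity at C-X-C chemokine receptor type 3 (Homo sapiens), read by FLIPR and calcium flux; a lower number here means a stronger inhibitor, a higher number a weaker inhibitor. Compound 3 `CC(=O)c1ccc(N2CCN(S(=O)(=O)C[C@]34CC[C@H](CC3=O)C4(C)C)CC2)nc1` carries a 5-acetylpyridin-2-yl ring. In this assay compound 3 gives only a limit, > 31600 nM. Compound 2 `CC1(C)[C@@H]2CC[C@@]1(CS(=O)(=O)N1CCN(c3ccc(Br)cn3)CC1)C(=O)C2` carries a 5-bromopyridin-2-yl ring instead, and in this assay compound 2 gives 1580 nM, so the step of an at least 20-fold higher number from compound 2 to compound 3 (1.30 log units; beyond the scatter) is large. Compound 1 `CC1(C)[C@@H]2CC[C@@]1(CS(=O)(=O)N1CCN(c3ncccc3C(F)(F)F)CC1)C(=O)C2` carries a 3-(trifluoromethyl)pyridin-2-yl ring. In this assay compound 1 gives only a limit, > 31600 nM. The step of an at least 20-fold lower number from compound 1 to compound 2 (1.30 log units; beyond the scatter) is large, whereas a step that the two limits leave unreadable from compound 1 to compound 3 cannot be sized, since (the limit of > 31600 nM in this assay, at which 2 of the 3 values shown sit).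

Compound 4 `CC1(C)[C@@H]2CC[C@@]1(CS(=O)(=O)N1CCN(c3ncc(C(F)(F)F)cn3)CC1)C(=O)C2` has not been measured. The change from compound 3 is 5-(trifluoromethyl)pyrimidin-2-yl in place of 5-acetylpyridin-2-yl on an amine nitrogen in a ring. Two of the measured steps bear on it: a 5-substituted pyridine with bromo sits at a measurable value in compound 2, while the acetyl and the trifluoromethyl headgroups in compound 3 and compound 1 both end at the limit. The estimated step of an at least 7.9-fold lower number from compound 3 to compound 4 (0.89 log units; beyond the scatter) is therefore expected to bring compound 4 back below the limit. For compound 4 in this assay the expected value is 4000 nM, within a range from 800 nM to 31600 nM.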

Compound 4, half-maximal inhibitory concentration: 316 nM
For compound 4 the middle estimate is 13-fold (1.10 log units) above the measured one; measured number below the stated range.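

The aromatic ring on this amine nitrogen can carry a group that does better than the 5-bromopyridin-2-yl ring, with a 5.0-fold lower number from compound 2 to compound 4 (0.70 log units; beyond the scatter), which makes compound 4 the strongest inhibitor of the four shown in this assay. A trifluoromethyl group alone does not settle the outcome, as compound 1 also carries one and stays far weaker, with an at least 100-fold lower number from compound 1 to compound 4 (2.00 log units; beyond the scatter). The acetyl-bearing ring of compound 3 gives way to the new ring with an at least 100-fold lower number from compound 3 to compound 4 (2.00 log units; beyond the scatter), and this step and the one from compound 1 each rest on a limit of the assay rather than on a number: the limit of > 31600 nM in this assay, at which 2 of the 4 values shown sit.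

As far as these compounds go, what stays open is how much of the gain in compound 4 belongs to the second ring nitrogen and how much to the trifluoromethyl group, as both change at once, and a 5-(trifluoromethyl)pyridin-2-yl ring or a 5-bromopyrimidin-2-yl ring would pull the two apart. Also open, from the compounds shown here alone, is how a nitrile, an amine or a carboxylic acid would fare in place of the trifluoromethyl group on the same ring.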